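The source may hold more compounds than are shown below. What is called first, only, known or untested is meant among the compounds shown, and "the series" means these compounds.

Compound 1 `Cc1ccc(-n2cc(COc3cccc4cnc(Nc5cccc(Cl)c5)nc34)nn2)c([N+](=O)[O-])c1`: 37000 nM
Compound 2 `COc1cccc(-n2cc(COc3cccc4cnc(Nc5cccc(Cl)c5)nc34)nn2)c1`: 20000 nM

In a functional assay on Caco-2 cells (Homo sapiens) for cytotoxicity, read by cell counting, with a stated time of 48 h (a lower number here means a stronger inhibitor, a higher number a weaker inhibitor), compound 2 stands at 20000 nM, within the scatter of compound 1 at 37000 nM. The two share their core and differ only in the group on an aromatic nitrogen. The next compound, compound 3 `Clc1cccc(Nc2ncc3cccc(OCc4cn(-c5cc(Cl)cc(Cl)c5)nn4)c3n2)c1`, changes that same group, with 3,5-dichlorophenyl in place of 3-methoxyphenyl on an aromatic nitrogen. Among the measured compounds shown here, only one measured step bears on this place, a 1.9-fold lower number from compound 1 to compound 2 (0.27 log units; within the scatter), and it replaced a quite different group there without leaving the scatter. For the measured compounds named here, no measured compound carries 3,5-dichlorophenyl, so that single step is thin evidence. Even so, no shift beyond the scatter is expected in this assay, in either direction. The expected step is a 1.1-fold lower number from compound 2 to compound 3 (0.05 log units; within the scatter). For compound 3 the estimated value is 18000 nM, with an expected range from 7000 nM to 45000 nM.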

Compound 3, half-maximal inhibitory concentration: 8000 nM
The estimate for compound 3 lay 2.3-fold (0.35 log units) above the measured number; the range from low to high includes it.
By their numbers in this assay, from the lowest: compound 3; then compounds 2 and 1 (each within the scatter of the next).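

In this assay, the group on the aromatic nitrogen can move the number beyond the scatter, which the earlier change at this place did not do: the new result is a 2.5-fold lower number from compound 2 to compound 3 (0.40 log units; beyond the scatter) and a 4.6-fold lower number from compound 1 to compound 3 (0.67 log units; beyond the scatter). Both steps are modest, yet they make compound 3 the strongest inhibitor of the three. The entering 3,5-dichlorophenyl keeps the six-membered aromatic ring of carbon only, so the gain comes with a change in what that ring carries, although nothing shown explains why this lowers the number.

It remains open whether both chlorine atoms contribute, since a single chlorine on this ring does not appear among these compounds. Also open, from the compounds shown here alone, is how a pyridine ring, or a phenyl ring bearing an amine or a carboxylic acid, would behave at this place.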